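This account rests on a few compounds, and the source may have more. Where it says the series, first, only, none or still open, it means among the compounds named here.

Of the compounds shown here, two built on one shared core have been measured in an assay on isolated protein for inhibition of Polyunsaturated fatty acid 5-lipoxygenase (Homo sapiens); on this read-out higher numbers stand for weaker inhibition and lower numbers for stronger inhibition. Compound 1 `O=C1CCCN(c2ccc(Cl)cc2)N1` gives 79000 nM, and compound 2 `O=C1CCCN(c2cccc(Br)c2)N1` gives 1800 nM. Compound 2 thus holds the lower of the two numbers, and compound 1 sits far above it, well beyond the scatter of repeated measurements. These two compounds differ from each other in more than one place, so nothing can be said about what any single change contributes; only the two values themselves are known.

Compound 3 `N#Cc1cccc(N2CCCC(=O)N2)c1` has not yet been tested. It differs from compound 2 by a single change: cyano in place of bromo on an aromatic carbon, (cyano in place of bromo on an aromatic carbon). For the measured compounds named here, no measured pair shows the effect of such a swap, so the direction of the step in this assay is open. A modest shift toward a higher number is expected, close to the edge of the scatter, with the step from compound 2 to compound 3 estimated at a 2.2-fold higher number from compound 2 to compound 3 (0.35 log units; beyond the scatter). Compound 3 is accordingly expected to give about 4000 nM, within a range from 1000 nM to 20000 nM.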

Compound 3, half-maximal inhibitory concentration: 9300 nM
For compound 3 the middle estimate is 2.3-fold (0.37 log units) below the measured one; the range from low to high includes it.
By their numbers in this assay, from the lowest: compound 2; then compound 3; then compound 1.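

Swapping bromo for cyano on this aromatic carbon, meta to a group of 7 heavy atoms, gives a 5.2-fold higher number from compound 2 to compound 3 (0.71 log units; beyond the scatter) in this assay. For the compounds shown here, this is the first comparison here in which only one place changes, so it shows that the read-out responds to the group at this position, with bromo giving the stronger inhibition of the two and the modest loss on moving to cyano lying beyond the usual scatter. Cyano brings one more heavy atom, a triple bond and a hydrogen-bond acceptor, but nothing measured here shows which of these differences matters, and no supporting data explain the step.

Going by these compounds, it remains open how other groups on this same aromatic carbon, such as chloro, methyl, an amine or a carboxylic acid, would compare with bromo and cyano. Also unsettled is whether the swap from bromo to cyano would produce a step of similar direction and size at another carbon of the ring.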